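Trifluoromethyl for fluoro on a methylsulfanyl core

The compounds below may be only part of what the source reports. "The series", "measured", "known", "first", "only" and "open" are said of these compounds alone.

Two compounds of this series have been characterised so far. Compound 1, `CS(=O)(=O)c1ccc(F)cc1NCC1=NCCN1`, is measured in an assay for binding affinity to Alpha-1A adrenergic receptor (Homo sapiens), read by radioligand binding (on this read-out higher numbers stand for weaker inhibition and lower numbers for stronger inhibition), and gives 813 nM. Compound 2, `CSc1ccc(F)cc1NCC1=NCCN1`, gives 33.1 nM in this assay. Going by the values given here, the single step between them, a 25-fold lower number from compound 1 to compound 2 (1.39 log units; beyond the scatter), arises from methylsulfanyl in place of methylsulfonyl on an aromatic carbon. On the numbers shown, compound 2 stands as the lowest of the two, with compound 1 as its nearest neighbour at the higher number.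

Compound 3, `CSc1ccc(C(F)(F)F)cc1NCC1=NCCN1`, has not yet been measured. It differs from compound 2 by trifluoromethyl in place of fluoro on an aromatic carbon, the exchange sitting para to a methylsulfanyl group. Among the compounds with values here, the only measured step concerns the sulfur group, not the fluoro position, so no step in hand bears directly on this change. With no guidance from the data, the step of a 1.5-fold higher number from compound 2 to compound 3 (0.18 log units; within the scatter) is expected to stay near the scatter in either direction. Compound 3 is therefore estimated at 50 nM in this assay, with a range from 12 nM to 200 nM.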

Compound 3, inhibition constant: 589 nM
Estimate against measurement, compound 3: 12-fold (1.07 log units) below; measured number outside the range, above it.
By their numbers in this assay, from the lowest: compound 2; then compounds 3 and 1 (each within the scatter of the next).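

In this assay, the place para to a methylsulfanyl group proves sensitive to what it carries: trifluoromethyl in place of fluoro gives an 18-fold higher number from compound 2 to compound 3 (1.25 log units; beyond the scatter), a large step towards weaker inhibition. The earlier compounds had shown such a sensitivity only at the sulfur group, through a 25-fold lower number from compound 1 to compound 2 (1.39 log units; beyond the scatter), so this result adds a second place on the aromatic ring where a single exchange moves the number beyond the scatter. Nothing in the data shown accounts for the size or direction of this step.

With fluoro and trifluoromethyl as the only groups shown at this place, it remains open how chloro, methyl or methoxy would read there in this assay, and whether any group could give a lower number than fluoro. It is also open whether the exchange of fluoro for trifluoromethyl would give a step of similar size on the core of compound 1, since it is shown here only with the methylsulfanyl group in place.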